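The source may hold more compounds than are shown below. What is called first, only, known or untested is meant among the compounds shown, and "the series" means these compounds.

Series notes. Compound 1 `COc1ccc(Cn2nc(Nc3cc(C)[nH]n3)c3ccccc3c2=O)cc1` carries a 4-methoxyphenyl group on the saturated chain carbon bound to the aromatic nitrogen of the shared core. In a functional assay on MCF7 cells (Homo sapiens) for cytotoxicity (on this read-out lower numbers stand for stronger inhibition and higher numbers for weaker inhibition), compound 1 gives > 30000 nM, which is a limit of the assay and not a number; one of the two values recorded so far sits at this limit (the limit of > 30000 nM in this assay, at which 1 of the 2 values shown sits). Compound 2 `Cc1cc(Nc2nn(CC(C)C)c(=O)c3ccccc23)n[nH]1` has isopropyl at that chain carbon, and in this assay compound 2 gives 4200 nM. The step of an at least 7.1-fold lower number from compound 1 to compound 2 (0.85 log units; beyond the scatter) is the only measured one; it exchanges the whole group on the chain carbon and says nothing about a change on the aryl ring itself.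

Compound 3 `CC(=O)Nc1ccc(Cn2nc(Nc3cc(C)[nH]n3)c3ccccc3c2=O)cc1` keeps that aryl ring and differs from compound 1 by acetamido in place of methoxy on an aromatic carbon, para to a large group. Among the measured compounds shown here, no measured step bears on this change, so the expectation rests on compound 1 standing at the limit. The change is expected to give a number no higher from compound 1 to compound 3 (the limit leaves the size open), with no shift beyond the scatter foreseen. Compound 3 is estimated at 30000 nM, within 8000 nM to 100000 nM, with a real chance that again only a limit is reported.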

Compound 3, half-maximal inhibitory concentration: > 30000 nM
Compound 3: no number, only a limit; the forecaster's own chance of this, stated with the estimate: 55%; the middle value sits exactly at the limit.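

Compound 1 and compound 3 both sit at a limit in this assay, not at a number, so no step can be read for acetamido in place of methoxy: the limit of > 30000 nM in this assay, at which 2 of the 3 values shown sit.

The compounds shown leave open whether this change on the aryl ring shifts the number at all in this assay, and where the true value of either compound lies.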